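Anilinopurine series, activation of histidine kinase 3

The compounds below may be only part of what the source reports. "The series", "measured", "known", "first", "only" and "open" are said of these compounds alone.

Measured so far:
compound 1 `COc1cccc(Nc2nc(Cl)nc3[nH]cnc23)c1`, 21000 nM
compound 2 `COc1cccc(Nc2nc(F)nc3[nH]cnc23)c1`, 19000 nM
compound 3 `Oc1ccc(Nc2nc(Cl)nc3[nH]cnc23)cc1`, 16500 nM

In an assay for activation of histidine kinase 3 (Arabidopsis thaliana), read by a beta-galactosidase reporter (a higher number here means that more compound is needed for the effect, a lower number that less compound is needed), compound 1 gives 21000 nM, the highest of the three numbers. The nearest value is that of compound 2, and the furthest that of compound 3; both gaps are within the scatter, so the three compounds cannot be placed in any order on this assay.

Compound 4 `Clc1cccc(Nc2nc(Cl)nc3[nH]cnc23)c1` differs from compound 1 in one place: chloro in place of methoxy on an aromatic carbon. Among the measured compounds shown here, no measured step touches the same place. For the measured compounds named here, the one measured step, a 1.1-fold lower number from compound 1 to compound 2 (0.04 log units; within the scatter), changes a different ring and is within the scatter; it gives no guidance on the exchange of the methoxy for a chloro. Going by the values given here, compound 3, with a hydroxy in place of the methoxy and at another position, sits within the scatter of compound 1, so the only change seen on this ring left the number where it was.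

No step beyond the scatter is therefore expected in this assay for compound 4, in either direction. Compound 4 is estimated at 20000 nM, with a range of 8000 nM to 50000 nM, which means an expected step of a 1.1-fold lower number from compound 1 to compound 4 (0.02 log units; within the scatter).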

Compound 4, half-maximal effective concentration: 10700 nM
Beside the measured number, compound 4's estimate is 1.9-fold (0.27 log units) above it; the range from low to high includes it.
By their numbers in this assay, from the lowest: compounds 4, 3, 2 and 1 (each within the scatter of the next).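

Among the compounds shown here, this is the first exchange that changes only the group on the aromatic carbon meta to a large group, and in this assay chloro in place of methoxy gives a 2.0-fold lower number from compound 1 to compound 4 (0.29 log units; within the scatter), so the change cannot be read as a real shift. Methoxy carries a hydrogen-bond acceptor and two heavy atoms, chloro no acceptor and one heavy atom, and the number stays within the scatter across that exchange, so the oxygen of the methoxy is not needed to hold a value in this range. Compound 3 could not show this, since its hydroxy differs from the methoxy of compound 1 in both group and place, and no measurement at hand explains the result of this exchange.

Going by these compounds, whether any group at this place can move the number beyond the scatter stays open, since methoxy and chloro alone give no direction for an amine, a carboxylic acid or a longer chain such as butoxy. Also open is whether the chloro on the shared core matters once the group on this ring is chloro, as the fluoro exchange is shown only with the methoxy in place.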